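Chloromethyl for hydrogen on the amide carbonyl of compound 1

The source may report more compounds than this note shows. Statements on the series, on what has been measured and on what is new or still open speak of the compounds shown alone.

Measured compounds:
compound 1, `O=CNc1ccc(C2=NNC(=O)CC2)cc1`, 3.74 ug/mL
compound 2, `CN1N=C(c2ccc(N)cc2)CCC1=O`, > 46.4 ug/mL

For the measured compounds named here, in a functional assay for inhibition, with Homo sapiens as the target (a higher number here means that more compound is needed for the effect, a lower number that less compound is needed), compound 1 gives 3.74 ug/mL, the only number in the set. For compound 2 the result is a limit of the assay, > 46.4 ug/mL, which is the limit of > 46.4 ug/mL in this assay, at which 1 of the 2 values shown sits. Compound 3, `O=C1CCC(c2ccc(NC(=O)CCl)cc2)=NN1`, has not yet been measured; it differs from compound 1 by chloromethyl in place of hydrogen on a carbonyl carbon. Going by the values given here, no step between measured compounds is available, so the size of this change is open. The step from compound 1 to compound 3 is expected to be a 1.1-fold lower number from compound 1 to compound 3 (0.03 log units; within the scatter), not beyond the scatter. For compound 3 the estimate is 3.5 ug/mL, with a range from 1 ug/mL to 12 ug/mL.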

Compound 3, half-maximal effective concentration: 0.39 ug/mL
For compound 3 the middle estimate is 9.0-fold (0.95 log units) above the measured one; the measured number lies below the stated range.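

Chloromethyl in place of hydrogen on a carbonyl carbon whose other neighbour is the amide-type nitrogen gives a 9.6-fold lower number from compound 1 to compound 3 (0.98 log units; beyond the scatter) in this assay. For the compounds shown here, this is the first step read at this position, and it shows that the position takes more than hydrogen, with less compound needed once chloromethyl stands there. Nothing shown bears on why the step has this size.

On these data alone, it remains open whether the step follows the chlorine or the added carbon. Methyl and bromomethyl on the same carbonyl carbon would separate the two.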